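Series notes: tail variation on the shared core

A few compounds are considered here, and "the series" means these few. Any claim that something is new, unique, unknown or untested is made for them only; others in the source may bear on it.

Compound 1 `C=C(Br)C(=O)Nc1cccc(-c2cn3nc(-c4ccccc4)sc3n2)c1` gives 1400 nM in a functional assay on HeLa cells (Homo sapiens) for inhibition, read by cell counting, with a stated time of 4 days; a lower number here means a stronger inhibitor, a higher number a weaker inhibitor; compound 2 `C=C(Br)C(=O)Nc1cccc(-c2cn3nc(-c4ccc(C)cc4)sc3n2)c1` gives 2000 nM, and compound 3 `C=C(Br)C(=O)Nc1cccc(-c2cn3nc(CCc4ccccc4)sc3n2)c1` gives 3300 nM. Compound 3 holds the highest of the three numbers: against compound 2 the gap is within the scatter, while a 2.4-fold higher number from compound 1 to compound 3 (0.37 log units; beyond the scatter) lies beyond it. Compound 4 `C=C(Br)C(=O)Nc1cccc(-c2cn3nc(Cc4ccc(OC)cc4)sc3n2)c1` differs from compound 3 by 4-methoxyphenyl in place of benzyl on a saturated chain carbon bound to an aromatic carbon, read one bond further out as phenethyl to 4-methoxybenzyl. Relevant steps are a 2.4-fold higher number from compound 1 to compound 3 (0.37 log units; beyond the scatter), a 1.7-fold higher number from compound 2 to compound 3 (0.22 log units; within the scatter) and a 1.4-fold higher number from compound 1 to compound 2 (0.15 log units; within the scatter); the chain shortening partly reverses the first, and a substituent on the aromatic ring mattered little. A small decrease, a 1.4-fold lower number from compound 3 to compound 4 (0.14 log units; within the scatter), is therefore expected in this assay. Compound 4 is estimated at 2400 nM, in the range 1100 nM to 5500 nM.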

Compound 4, half-maximal inhibitory concentration: 2300 nM
Estimate against measurement, compound 4: 1.0-fold (0.02 log units) above; low and high end bracket the measured number.
By their numbers in this assay, from the lowest: compounds 1, 2, 4 and 3 (each within the scatter of the next, the first and the last beyond it).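

In this assay, the 4-methoxybenzyl tail cannot be told apart from any earlier tail: a 1.4-fold lower number from compound 3 to compound 4 (0.16 log units; within the scatter), a 1.2-fold higher number from compound 2 to compound 4 (0.06 log units; within the scatter) and a 1.6-fold higher number from compound 1 to compound 4 (0.22 log units; within the scatter) all lie within the scatter. This position therefore tolerates an oxygen and a hydrogen-bond acceptor entering on the tail, with no difference that can be read. Compound 4 is also within the scatter of both compound 1 and compound 3, although those two differ beyond it.

On these data alone, whether an amine or a carboxylic acid at this position would move the number beyond the scatter stays open. No evidence on the cause of these small steps is available.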